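The source may report more compounds than this note shows. Statements on the series, on what has been measured and on what is new or still open speak of the compounds shown alone.

Measured so far:
compound 1 `CC(C)=CCC/C(C)=C/CC/C(C)=C/CSc1ccccc1C(=O)N[C@@H](C)C(=O)OC(C)CCOc1no[n+]([O-])c1S(=O)(=O)c1ccccc1` — 11100 nM
compound 2 `CC(C)=CCC/C(C)=C/CC/C(C)=C/CSc1ccccc1C(=O)N[C@@H](C)C(=O)OCCOCCOc1no[n+]([O-])c1S(=O)(=O)c1ccccc1` — 7680 nM
compound 3 `CC(C)=CCC/C(C)=C/CC/C(C)=C/CSc1ccccc1C(=O)NCC(=O)OC(C)CCOc1no[n+]([O-])c1S(=O)(=O)c1ccccc1` — 9110 nM

All three were read in a functional assay on MCF7 cells (Homo sapiens) for cytotoxicity, read by MTT assay, with a stated time of 48 h; a lower number here means a stronger inhibitor, a higher number a weaker inhibitor. Compound 1 and compound 3 share a core and differ only by hydrogen in place of methyl on a saturated chain carbon bound to an amide-type nitrogen and a carbonyl carbon; the step of a 1.2-fold lower number from compound 1 to compound 3 (0.09 log units; within the scatter) is the size it made. Compound 2 has a different core; the difference between the cores of compound 1 and compound 2 is not broken down here. Compound 2 gives 7680 nM in this assay, which sits within the scatter of both compound 1 and compound 3.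

Not yet measured is compound 4 `CC(C)=CCC/C(C)=C/CC/C(C)=C/CSc1ccccc1C(=O)NCC(=O)OCCOCCOc1no[n+]([O-])c1S(=O)(=O)c1ccccc1`, which differs from compound 2 by hydrogen in place of methyl on a saturated chain carbon bound to an amide-type nitrogen and a carbonyl carbon, the same change as from compound 1 to compound 3, at a place described in identical words. The expected step is a 1.2-fold lower number from compound 2 to compound 4 (0.08 log units; within the scatter), set beside a 1.2-fold lower number from compound 1 to compound 3 (0.09 log units; within the scatter) and resting on it. For compound 4 in this assay the estimate is 6400 nM, expected between 3500 nM and 12000 nM.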

Compound 4, half-maximal inhibitory concentration: 6590 nM
Compound 4: the middle estimate sits 1.0-fold (0.01 log units) below what was measured, and the stated range covers the measured number.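

In this assay, hydrogen in place of methyl on a saturated chain carbon bound to an amide-type nitrogen and a carbonyl carbon gives a 1.2-fold lower number from compound 2 to compound 4 (0.07 log units; within the scatter), and the same change on the other core agrees with it: the same change on two cores in this assay, a 1.2-fold lower number (0.09 log units; within the scatter) from compound 1 to compound 3 and a 1.2-fold lower number (0.07 log units; within the scatter) from compound 2 to compound 4, 1.0-fold (0.02 log units) apart, within the scatter of two such steps. Across these two cores, then, the change carries over as a step that stays within the scatter each time. Among these compounds, that agreement shows only that the change does little on either core; it does not show a real effect being transferred, and it says nothing about any third core.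

The compounds shown leave open whether an isopropyl or benzyl group, a carboxylic acid or an amine on that carbon would give a step beyond the scatter. They also leave open whether a longer chain in the ester part would change how the step carries over.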